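Replacing a carbamoyl side group with a fluorobenzyl ether

The source may report more compounds than this note shows. Statements on the series, on what has been measured and on what is new or still open speak of the compounds shown alone.

Compound 3 `Cc1nn(-c2ncnc3nc[nH]c23)c2c1C(C(=O)Nc1ccccc1)CC(=O)N2` gives 10 nM in a functional assay on HEK293 cells for agonist activity at G-protein coupled receptor 39 (Homo sapiens), read by scintillation proximity assay and inositol phosphate accumulation, with a stated time of 75 min, in the presence of a further agent that is not named here (on this read-out higher numbers stand for an effect only at larger amounts of compound and lower numbers for an effect already at smaller amounts), the highest number among the three measured compounds. Compound 2 `Cc1nn(-c2ncnc3nc[nH]c23)c2c1C(OCc1ccc(Cl)cc1Cl)CC(=O)N2` gives 4 nM and compound 1 `Cc1nn(-c2ncnc3nc[nH]c23)c2c1C(OCC(=O)c1ccc(F)cc1)CC(=O)N2` gives 3 nM in this assay. Compound 4 `Cc1nn(-c2ncnc3nc[nH]c23)c2c1C(OCc1ccccc1F)CC(=O)N2` carries the change ((2-fluorobenzyl)oxy in place of phenylcarbamoyl on a saturated ring carbon). The most relevant measured step runs the other way: a 2.5-fold higher number from compound 2 to compound 3 (0.40 log units; beyond the scatter). The step of a 1.3-fold higher number from compound 1 to compound 2 (0.12 log units; within the scatter) shows that two different ether side groups give numbers within the scatter of each other. Because of a 2.5-fold higher number from compound 2 to compound 3 (0.40 log units; beyond the scatter) a lower number is expected for compound 4, a step estimated as a 2.5-fold lower number from compound 3 to compound 4 (0.40 log units; beyond the scatter). Compound 4 is therefore estimated at 4 nM, with a range from 1.5 nM to 12 nM.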

Compound 4, half-maximal effective concentration: 4 nM
Beside the measured number, compound 4's estimate shows no gap at the digits printed; the range from low to high includes it.
By their numbers in this assay, from the lowest: compounds 1, 2 and 4 (each within the scatter of the next); then compound 3.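

On this saturated ring carbon, the change from phenylcarbamoyl to (2-fluorobenzyl)oxy matches the earlier move from ether to amide in size but runs the opposite way in this assay (a 2.5-fold lower number from compound 3 to compound 4 (0.40 log units; beyond the scatter)). The ether side groups of the other compounds stay within the scatter of this one (no change at the digits printed from compound 2 to compound 4 (within the scatter); a 1.3-fold higher number from compound 1 to compound 4 (0.12 log units; within the scatter)), so quite different ethers are tolerated here. No measurement shown explains this result. The compounds shown leave open how an amine or a carboxylic acid on this ring carbon would read, and likewise an ether with a longer chain.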